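A few compounds are considered here, and "the series" means these few. Any claim that something is new, unique, unknown or untested is made for them only; others in the source may bear on it.

Measured so far:
Compound 1 `CCc1nc(C(C)C)c2n1CCN([C@@H](C(=O)NC)c1ccccc1)C2CCc1ccc(C(F)(F)F)cc1`, 10000 nM
Compound 2 `CCc1nc(SC)c2n1CCN([C@@H](C(=O)NC)c1ccccc1)[C@H]2CCc1ccc(C(F)(F)F)cc1`, 85 nM

In a functional assay on CHO cells for antagonist activity at Orexin/Hypocretin receptor type 1 (Homo sapiens), read by FLIPR and calcium flux (a lower number here means a stronger inhibitor, a higher number a weaker inhibitor), compound 1 gives the highest number of the two, and compound 2 gives a number that lies far below it, well beyond the scatter. Compound 3 `CCc1ncc2n1CCN([C@@H](C(=O)NC)c1ccccc1)C2CCc1ccc(C(F)(F)F)cc1` differs from compound 1 by a single change: hydrogen in place of isopropyl on an aromatic carbon. No step between two measured compounds reports what this change alone does, so the expectation rests on the two numbers shown. Removing the isopropyl is expected to lower the number somewhat, by a 6.7-fold lower number from compound 1 to compound 3 (0.82 log units; beyond the scatter), so compound 3 is estimated at 1500 nM, within 150 nM to 10000 nM.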

Compound 3, half-maximal inhibitory concentration: 10000 nM
Estimate against measurement, compound 3: 6.7-fold (0.82 log units) below; the range from low to high includes it.
By their numbers in this assay, from the lowest: compound 2; then compounds 1 and 3 (each within the scatter of the next).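

In this assay putting hydrogen in place of isopropyl on this aromatic carbon gives no change at the digits printed from compound 1 to compound 3 (within the scatter) and so brings no gain at this position. The earlier pair could not show this, since compound 2 differs from compound 1 in more than one place. Still open, from the compounds shown here alone, is what an amine, a carboxylic acid or a longer chain would do on this same carbon, and whether the ethyl group can be changed with as little effect. No supporting measurement bears on why the isopropyl can go without any change in this number.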